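The source may report more compounds than this note shows. Statements on the series, on what has been measured and on what is new or still open speak of the compounds shown alone.

Measured compounds in an assay on CHO cells for antagonist activity at transient receptor potential cation channel subfamily V member 1 (Homo sapiens), read by FLIPR; on this read-out higher numbers stand for weaker inhibition and lower numbers for stronger inhibition:
- compound 1 `CC1CCN(c2nc(C(F)(F)F)ccc2CNC(=O)C(c2ccc(NS(C)(=O)=O)c(F)c2)C2CCCC2)CC1`: 88.7 nM
- compound 2 `CS(=O)(=O)Nc1ccc(C(C(=O)NCc2ccc(C(F)(F)F)nc2SC2CCCCC2)C2CCCC2)cc1F`: 103 nM
- compound 3 `Cc1ccccc1C(C(=O)NCc1ccc(C(F)(F)F)nc1N1CCC(C)CC1)c1ccc(NS(C)(=O)=O)c(F)c1`: 42.9 nM

Compound 2 gives the highest of the three numbers in this assay, though the step of a 1.2-fold higher number from compound 1 to compound 2 (0.06 log units; within the scatter) is not resolved; against compound 3 the values of compound 2 and compound 3 differ by more than the scatter.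

Compound 4 `Cc1ccc(C(C(=O)NCc2ccc(C(F)(F)F)nc2SC2CCCCC2)c2ccc(NS(C)(=O)=O)c(F)c2)cc1` is not yet measured. It differs from compound 2 in one place: 4-methylphenyl in place of cyclopentyl on a saturated chain carbon bound to an aromatic carbon and a carbonyl carbon

Among the measured compounds shown here, the only measured step of this kind is from compound 1 to compound 3, where a 2-methylphenyl replaced the cyclopentyl on the same saturated chain carbon: a 2.1-fold lower number from compound 1 to compound 3 (0.32 log units; beyond the scatter). That step stands on a different core group, and the entering ring here carries its methyl at a different position, so the transfer is approximate. A modest lowering of the number is nevertheless expected for compound 4, estimated as a 1.9-fold lower number from compound 2 to compound 4 (0.27 log units; within the scatter), giving an expected value of 55 nM with a range of 25 nM to 130 nM.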

Compound 4, inhibition constant: 7.5 nM
Beside the measured number, compound 4's estimate is 7.3-fold (0.87 log units) above it, and the stated range ends above it.
By their numbers in this assay, from the lowest: compound 4; then compound 3; then compounds 1 and 2 (each within the scatter of the next).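

In this assay, among the compounds shown here, the saturated chain carbon bound to an aromatic carbon and a carbonyl carbon responds far more strongly than the earlier compounds indicated: 4-methylphenyl in place of cyclopentyl gives a 14-fold lower number from compound 2 to compound 4 (1.14 log units; beyond the scatter), a large step, whereas 2-methylphenyl in place of cyclopentyl on the core of compound 1 gave a 2.1-fold lower number from compound 1 to compound 3 (0.32 log units; beyond the scatter). The step replaces a five-membered non-aromatic ring with a six-membered aromatic ring, and neither group has hydrogen-bond donors, hydrogen-bond acceptors or a net charge. No available measurement explains the size of this step.

The compounds shown do not separate the position of the methyl from the group on the aromatic carbon of the core, since each methylphenyl appears with only one such group. Also open, on these data alone, is how an unsubstituted phenyl or a 4-chlorophenyl would read at this carbon.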